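The source may report more compounds than this note shows. Statements on the series, on what has been measured and on what is new or still open speak of the compounds shown alone.

Measured compounds:
compound 1, `O=C(C1CC1)N1CCN(Cc2nc3ccccc3n2Cc2ccccc2C(F)(F)F)CC1`, 56.3%
compound 2, `Cc1ccccc1Cn1c(CN2CCN(C(=O)C3CC3)CC2)nc2ccccc21`, 29.1%
compound 3, `COc1cccc(Cn2c(CN3CCN(C(=O)C4CC4)CC3)nc3ccccc32)c1`, 44.4%

In an assay on isolated protein for inhibition of aldehyde dehydrogenase 1A1 (Homo sapiens), read by spectrophotometry, tested at 10 uM (on this read-out lower numbers stand for less inhibition and higher numbers for more inhibition at the one concentration tested (going by the name of the read-out)), compound 3 stands second highest of the three numbers. Compound 1 lies nearest, and the step of a number 11.9 percentage points lower from compound 1 to compound 3 (beyond the scatter) is beyond the scatter. Compound 2 lies furthest, and the step of a number 15.3 percentage points higher from compound 2 to compound 3 (beyond the scatter) is also beyond the scatter. Between compound 1 and compound 2 the step of a number 27.2 percentage points lower from compound 1 to compound 2 (beyond the scatter) is the largest of the three.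

Compound 4, `O=C(C1CC1)N1CCN(Cc2nc3ccccc3n2Cc2ccccc2F)CC1`, has not yet been measured in this assay. It differs from compound 3 in one place: 2-fluorophenyl in place of 3-methoxyphenyl on a saturated chain carbon bound to an aromatic nitrogen.

For the measured compounds named here, two measured steps bear on this change, both ending at compound 3 and both replacing a 2-substituted phenyl on the same saturated chain carbon by the 3-methoxyphenyl. One went down from compound 1 by a modest amount, the other went up from compound 2 by a modest amount. Compound 4 returns to a 2-substituted phenyl, but with a substituent seen in neither of those compounds, so the direction is not settled; the two earlier steps point opposite ways and roughly cancel.

Compound 4 is therefore expected to sit near compound 3, at about 42%, within 22% to 62%, which would mean an estimated step of a number 2.4 percentage points lower from compound 3 to compound 4 (within the scatter).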

Compound 4, a percentage reported as inhibition, at one concentration (the size of the read-out at that concentration, not a potency): 40.7%
For compound 4 the middle estimate is 1.3 percentage points above the measured one, and the stated range covers the measured number.
By their numbers in this assay, from the lowest: compound 2; then compounds 4 and 3 (each within the scatter of the next); then compound 1.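

In this assay, 2-fluorophenyl in place of 3-methoxyphenyl on the saturated chain carbon bound to an aromatic nitrogen gives a number 3.7 percentage points lower from compound 3 to compound 4 (within the scatter), so these two quite different groups are not told apart at this position. Fluoro in place of methyl on the aromatic carbon gives a number 11.6 percentage points higher from compound 2 to compound 4 (beyond the scatter), while fluoro in place of trifluoromethyl gives a number 15.6 percentage points lower from compound 1 to compound 4 (beyond the scatter), which shows that the single substituent of the 2-substituted benzyl group moves the inhibition in either direction, with fluoro lying between the other two; compound 3 goes against any reading that fluorine is needed to rise beyond compound 2, as it carries none. Nothing available accounts for these differences.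

The compounds shown leave open how much of the value of compound 3 comes from the methoxy group and how much from where it sits, a question that a 2-methoxyphenyl or a 3-fluorophenyl at this position would separate. They also leave open what a plain phenyl or a 2-chlorophenyl would give in this assay.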